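Removing a methyl from the core of two naphthoquinone-type amides

The source may report more compounds than this note shows. Statements on the series, on what has been measured and on what is new or still open speak of the compounds shown alone.

Measured so far:
- compound 1, `COC1=C(CC(C)(C)CNC(=O)c2ccccc2OC)C(=O)c2ccccc2C1=O`: in a functional assay on MCF7 cells (Homo sapiens) for cytotoxicity, read by resazurin assay, with a stated time of 3 days (on this read-out higher numbers stand for weaker inhibition and lower numbers for stronger inhibition), compound 1 gives 70700 nM
- compound 2, `COC1=C(CC(C)(C)CNC(=O)c2ccc3ccccc3c2OC)C(=O)c2ccccc2C1=O`: compound 2 gives 95700 nM
- compound 3, `COc1ccccc1C(=O)NCC(C)(C)CC1=C(O)C(=O)c2ccccc2C1=O`: compound 3 gives 111000 nM

All three numbers lie close together; the three differences among them are each within the scatter, so no ordering among compound 1, compound 2 and compound 3 can be read from them.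

Compound 1 and compound 3 differ in one place, (hydrogen in place of methyl on an oxygen on an unsaturated carbon), and the step this made was a 1.6-fold higher number from compound 1 to compound 3 (0.20 log units; within the scatter). Compound 1 and compound 2 are built on different cores; the difference between the two cores is not broken down here.

Compound 4, `COc1c(C(=O)NCC(C)(C)CC2=C(O)C(=O)c3ccccc3C2=O)ccc2ccccc12`, has not yet been measured. It stands to compound 2 as compound 3 stands to compound 1: the difference is hydrogen in place of methyl on an oxygen on an unsaturated carbon, the same change at the same kind of place. Among the compounds with values here, the expectation for compound 4 therefore rests on the single earlier example, where the step of a 1.6-fold higher number from compound 1 to compound 3 (0.20 log units; within the scatter) was small, and the estimated step is a 1.6-fold higher number from compound 2 to compound 4 (0.20 log units; within the scatter). Because compound 2 sits at 95700 nM, compound 4 is expected to come out near 150000 nM, most likely between 60000 nM and 350000 nM. Within the data shown here, with only one prior instance of this change, this estimate carries real uncertainty.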

Compound 4, half-maximal inhibitory concentration: 39800 nM
Compound 4: middle estimate off by 3.8-fold (0.58 log units), on the high side, and the stated range ends above it.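

In this assay the methoxy to hydroxy change on the core gives a 2.4-fold lower number from compound 2 to compound 4 (0.38 log units; beyond the scatter), so on the core of compound 2, losing the methyl goes with a modest gain in inhibition. Within the data shown here, on the core of compound 1 the same change gives no step that can be told from repeat-measurement scatter, and the two results do not match, so the effect of this change did not carry from one core to the other: the same change on two cores in this assay, a 1.6-fold higher number (0.20 log units; within the scatter) from compound 1 to compound 3 and a 2.4-fold lower number (0.38 log units; beyond the scatter) from compound 2 to compound 4, 3.8-fold (0.58 log units) apart, beyond the scatter of two such steps. This rests on one pair per core, so it shows that the step depends on the surrounding structure in these four compounds, but it does not show why, nor which of the two results is more typical of the series.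

The compounds shown leave open what other groups on that same oxygen would do, for example an ethyl group or a longer chain in place of the methyl. Also open, as far as these compounds go, is whether the lower number of compound 4 would hold if the amide part carried a further group, such as an amine or a carboxylic acid.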